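The source may hold more compounds than are shown below. What is called first, only, known or untested is meant among the compounds shown, and "the series" means these compounds.

Compound 1, `COc1cc(NC(C)CCCNC(=O)NNC(=O)Nc2ccc(Cl)c(C(F)(F)F)c2)c2ncccc2c1`: in a functional assay on SW-620 cells (Homo sapiens) for inhibition, read by MTT assay, with a stated time of 4 days (on this read-out higher numbers stand for weaker inhibition and lower numbers for stronger inhibition), compound 1 gives 15000 nM.
Compound 2, `COc1cc(NC(C)CCCNC(=O)NNC(=O)NCCCO)c2ncccc2c1`: in this assay compound 2 gives > 100000 nM.

Compound 2 stands at the limit of this assay, (the limit of > 100000 nM in this assay, at which 1 of the 2 values shown sits), so no number is known for it, only that its inhibition is too weak to be measured. Within the data shown here, the one measured step that bears on it is an at least 6.6-fold higher number from compound 1 to compound 2 (0.82 log units; beyond the scatter), where a 3-hydroxypropyl group replaced an aromatic group and the weakening was at least modest.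

Compound 3, `COc1cc(NC(C)CCCNC(=O)NNC(=O)NC(CO)(CO)CO)c2ncccc2c1`, is reached from compound 2 by 2-hydroxy-1,1-bis(hydroxymethyl)ethyl in place of 3-hydroxypropyl on an amide-type nitrogen. Among the measured compounds shown here, the change adds further hydroxyl groups of the same hydroxyalkyl kind that already gave a limit in compound 2, and no measured step shows such a group restoring inhibition. The expected step from compound 2 to compound 3 is therefore none beyond the scatter, a step that the limit leaves unreadable from compound 2 to compound 3, with compound 3 most likely also reported only as a limit. Compound 3 is estimated at 150000 nM, between 60000 nM and 400000 nM.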

Compound 3, half-maximal inhibitory concentration: > 100000 nM
Compound 3: a limit, no number (the forecaster's own chance of this, stated with the estimate: 85%); the middle value does not contradict the limit.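

In this assay compound 3 gives > 100000 nM, which is a limit and not a number. The loss of inhibition now has a second example, an at least 6.6-fold higher number from compound 1 to compound 3 (0.82 log units; beyond the scatter), so it appears with 2-hydroxy-1,1-bis(hydroxymethyl)ethyl as well as with 3-hydroxypropyl on this amide-type nitrogen. The step between compound 2 and compound 3 cannot be read, since both compounds rest on the same limit: the limit of > 100000 nM in this assay, at which 2 of the 3 values shown sit.

As far as these compounds go, how far compound 2 and compound 3 lie past that limit, and whether they differ from each other, stays open. Also open, from the compounds shown here alone, is whether an unsubstituted phenyl, a benzyl or a longer chain ending in an amine would keep inhibition closer to that of compound 1.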